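This account rests on a few compounds, and the source may have more. Where it says the series, first, only, none or still open, it means among the compounds named here.

Measured so far:
compound 1 `O=C(c1ccc(Cl)c(C(F)(F)F)c1)N1CCC(n2cncc2-c2ccc(OS(=O)(=O)c3ccccc3)cc2)CC1`, which in an assay on HEK293 cells for antagonist activity at P2X purinoceptor 7 (Homo sapiens), read by fluorescence, with a stated time of 2 h (a higher number here means a weaker inhibitor, a lower number a stronger inhibitor), gives 702 nM;
compound 2 `N#Cc1cccc(S(=O)(=O)Oc2ccc(-c3cncn3C3CCN(C(=O)c4ccc(Cl)c(C(F)(F)F)c4)CC3)cc2)c1`, which in this assay gives 73 nM.

Compound 2 stands lowest of these two numbers. For the measured compounds named here, its nearest neighbour is compound 1, and the one measured step, a 9.6-fold lower number from compound 1 to compound 2 (0.98 log units; beyond the scatter), came with cyano in place of hydrogen on an aromatic carbon.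

Compound 3 `CCN(CC)C(=O)c1cccc(S(=O)(=O)Oc2ccc(-c3cncn3C3CCN(C(=O)c4ccc(Cl)c(C(F)(F)F)c4)CC3)cc2)c1` has not yet been measured. It differs from compound 2 in one place: diethylcarbamoyl in place of cyano on an aromatic carbon, on an aromatic carbon of a six-membered aromatic ring of carbon only, meta to a large group. Going by the values given here, only one measured step bears on this position, a 9.6-fold lower number from compound 1 to compound 2 (0.98 log units; beyond the scatter), and it shows that what sits there moves the number well beyond the scatter. Nothing measured shows what diethylcarbamoyl does there, so the direction of the new step is uncertain. Compound 3 is expected to sit between its two neighbours, nearer compound 2. For compound 3 the expected step is a 2.7-fold higher number from compound 2 to compound 3 (0.44 log units; beyond the scatter) in this assay. Compound 3 is estimated at 200 nM, in a range from 50 nM to 800 nM.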

Compound 3, half-maximal inhibitory concentration: 202 nM
Estimate against measurement, compound 3: 1.0-fold (0.00 log units) below, within the range that was stated.
By their numbers in this assay, from the lowest: compound 2; then compound 3; then compound 1.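

Diethylcarbamoyl in place of hydrogen also gives a 3.5-fold lower number from compound 1 to compound 3 (0.54 log units; beyond the scatter) in this assay, so the lower number at this aromatic carbon is no longer tied to cyano alone. The two groups are not interchangeable, however: exchanging cyano for diethylcarbamoyl gives a 2.8-fold higher number from compound 2 to compound 3 (0.44 log units; beyond the scatter), which gives back part of what cyano brought, and the order at this position runs from cyano, through diethylcarbamoyl, to hydrogen, with the lowest number first. The compounds shown offer nothing that explains this order, and no separate measurement bears on why the two groups differ.

On these data alone, with only hydrogen, cyano and diethylcarbamoyl to compare, it stays open whether the number at this carbon follows the size of the group or something else about it, and what a primary carboxamide, a dimethylcarbamoyl group, an amine or a carboxylic acid would do in the same place. As far as these compounds go, it also stays open whether cyano and diethylcarbamoyl would keep this order on another carbon of the same six-membered aromatic ring.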